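Second Methyl on the Amino Aryl Ring

The source may hold more compounds than are shown below. What is called first, only, known or untested is meant among the compounds shown, and "the series" means these compounds.

Three compounds have been measured in a functional assay on the whole organism (Ear, strain Kunming) for inhibition, with Mus musculus as the target, with stated times of 1 h and 30 min, at a dose of 200 mg/kg by the oral route; a higher number here means more inhibition at the dose given (going by the name of the read-out), a lower number less inhibition:

Compound 1 `COc1ccc(C2(O)/C(=C/c3ccccc3)CCCC2CN(C)c2ccccc2)cc1` gives 26.5%.
Compound 2 `COc1ccc(C2(O)/C(=C/c3ccccc3)CCCC2CN(C)c2ccc(C)cc2)cc1` gives 26.5%.
Compound 3 `COc1ccc(C2(O)/C(=C/c3ccc(C)cc3)CCCC2CN(C)c2ccccc2)cc1` gives 16.3%.

Compound 3 stands lowest of the three. The step of a number 10.2 percentage points lower from compound 1 to compound 3 (beyond the scatter) lies beyond the scatter, and compound 2 likewise reads higher than compound 3. Compound 4 `COc1ccc(C2(O)/C(=C/c3ccc(C)cc3)CCCC2CN(C)c2ccc(C)cc2)cc1` differs from compound 3 by methyl in place of hydrogen on an aromatic carbon. Among the measured compounds shown here, the one step that bears on this change is no change at the digits printed from compound 1 to compound 2 (within the scatter), the same change on the same ring of the shared core, which stayed within the scatter. The step of a number 0.7 percentage points higher from compound 3 to compound 4 (within the scatter) is therefore expected to show no movement beyond the scatter. Compound 4 is estimated at 17%, with a range from 7% to 28%.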

Compound 4, a percentage reported as inhibition, in the whole organism at one dose (the size of the read-out at that dose, not a potency): 29.9%
For compound 4 the middle estimate is 12.9 percentage points below the measured one, and the stated range ends below it.
By their numbers in this assay, from the lowest: compound 3; then compounds 1, 2 and 4 (each within the scatter of the next).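

In this assay, the change from methyl(phenyl)amino to methyl(4-methylphenyl)amino, silent on the core of compound 1, now gives a number 13.6 percentage points higher from compound 3 to compound 4 (beyond the scatter), while the same methyl on the core of compound 2 gives a number 3.4 percentage points higher from compound 2 to compound 4 (within the scatter). Even so, the effect of this methyl is not shown to depend on the other methyl: the same change on two cores in this assay, no change at the digits printed (within the scatter) from compound 1 to compound 2 and a number 13.6 percentage points higher (beyond the scatter) from compound 3 to compound 4, 13.6 percentage points apart, within the scatter of two such steps

The same caution applies to the methyl on the other ring: the same change on two cores in this assay, a number 10.2 percentage points lower (beyond the scatter) from compound 1 to compound 3 and a number 3.4 percentage points higher (within the scatter) from compound 2 to compound 4, 13.6 percentage points apart, within the scatter of two such steps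

Going by these compounds, whether anything other than methyl at this position, such as chlorine, methoxy or an amine, would behave alike remains open. So does whether a longer chain there would.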